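The source may report more compounds than this note shows. Statements on the series, on what has been measured and on what is new or still open speak of the compounds shown alone.

Compound 1 `COc1cc(-c2nnc3n2NC(c2ccco2)C(C(=O)c2ccccc2C)S3)cc(OC)c1OC` gives in a functional assay on PC-3 cells (Homo sapiens) for cytotoxicity, read by MTT assay, with a stated time of 48 h (on this read-out lower numbers stand for stronger inhibition and higher numbers for weaker inhibition), a value of 88400 nM. Compound 2 `COc1cc(-c2nnc3n2NC(c2ccco2)C(C(=O)c2ccc(Cl)cc2)S3)cc(OC)c1OC` gives 67800 nM. Compound 3 `COc1cc(-c2nnc3n2NC(c2ccco2)C(C(=O)c2ccccc2)S3)cc(OC)c1OC` gives 64300 nM.

All three numbers lie within the scatter of one another: a 1.3-fold lower number from compound 1 to compound 2 (0.12 log units; within the scatter), a 1.4-fold lower number from compound 1 to compound 3 (0.14 log units; within the scatter) and a 1.1-fold lower number from compound 2 to compound 3 (0.02 log units; within the scatter). Compound 3 is thus not separated from either neighbour. Compound 4 `COc1cc(-c2nnc3n2NC(c2ccco2)C(C(=O)c2cccc4ccccc24)S3)cc(OC)c1OC` differs from compound 3 by naphthalen-1-yl in place of phenyl on a carbonyl carbon. The measured steps also touch the ring on the carbonyl carbon, but only through a methyl or a chloro substituent, and none of them moved the number beyond the scatter. Among the compounds with values here, no measured step adds a second ring, so the present change is only loosely covered. On that basis compound 4 is expected to show no step beyond the scatter, a 1.1-fold lower number from compound 3 to compound 4 (0.03 log units; within the scatter). Compound 4 is estimated at 60000 nM, within 25000 nM to 150000 nM.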

Compound 4, half-maximal inhibitory concentration: > 100000 nM
Compound 4: only a limit was reported; the forecaster's own chance of this, stated with the estimate: 15%; middle value at least 1.6-fold (0.22 log units) away from the limit.
By their numbers in this assay, from the lowest: compounds 3, 2 and 1 (each within the scatter of the next). At a limit, above all of these: compound 4.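

In this assay compound 4 gives only a limit, not a number: the limit of > 100000 nM in this assay, at which 1 of the 4 values shown sits. The steps read an at least 1.5-fold higher number from compound 3 to compound 4 (0.19 log units; that floor lies within the scatter), an at least 1.4-fold higher number from compound 2 to compound 4 (0.16 log units; that floor lies within the scatter) and an at least 1.1-fold higher number from compound 1 to compound 4 (0.05 log units; that floor lies within the scatter). A second ring on the carbonyl carbon, as naphthalen-1-yl, therefore leaves the value without an upper end, which the methyl and chloro substituents did not, yet no separation beyond the scatter is established.

Going by these compounds, how far compound 4 actually lies from the others remains open. So does whether an amine or a carboxylic acid on the ring at this position would move the number beyond the scatter.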